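A few compounds are considered here, and "the series" means these few. Any claim that something is new, unique, unknown or untested is made for them only; others in the source may bear on it.

Measured so far:
- Compound 1, `CC(Sc1nc2nn(C3COC3)cc2c(=O)n1-c1ccccc1)c1ccccc1` — in an assay on isolated protein for inhibition of Retinaldehyde dehydrogenase 3 (Homo sapiens) (on this read-out lower numbers stand for stronger inhibition and higher numbers for weaker inhibition), compound 1 gives 109 nM
- Compound 2, `CC(Sc1nc2nn(C3(C)COC3)cc2c(=O)n1-c1ccccc1)c1ccccc1` — in this assay compound 2 gives 50 nM
- Compound 3, `Cn1ncc2c(=O)n(-c3ccccc3)c(OCc3cccc(F)c3)nc21` — in this assay compound 3 gives 1700 nM

Compound 1 stands second among these three numbers. Its nearest neighbour is compound 2, reached by one change only: a 2.2-fold lower number from compound 1 to compound 2 (0.34 log units; beyond the scatter). The furthest is compound 3, whose number is far higher but which differs from compound 1 in several places at once, so its two values alone cannot be tied to any single change.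

The compound not yet measured, compound 4, is `CC(Sc1nc2nn(C3COC3)cc2c(=O)n1-c1ccccc1)c1ccccn1`. It differs from compound 1 in one place: pyridin-2-yl in place of phenyl on a saturated chain carbon bound to a saturated chain carbon and a sulfur

For the measured compounds named here, none of the measured steps covers this kind of change. Going by the values given here, the only single step known here swaps a hydrogen for a methyl on a saturated ring carbon, a different part of the shared core, and compound 3 is too far removed to serve as a guide. With nothing to lean on, the expectation for compound 4 in this assay is a number close to that of compound 1, with a step of a 1.2-fold higher number from compound 1 to compound 4 (0.08 log units; within the scatter) that may well stay inside the usual scatter. Compound 4 is therefore estimated at 130 nM, in the range 40 nM to 450 nM.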

Compound 4, half-maximal inhibitory concentration: 480 nM
Compound 4: the middle estimate sits 3.7-fold (0.57 log units) below what was measured; measured number above the stated range.
By their numbers in this assay, from the lowest: compound 2; then compound 1; then compound 4; then compound 3.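

In this assay, the group on the saturated chain carbon bound to a saturated chain carbon and a sulfur proves sensitive to a small edit: replacing phenyl with pyridin-2-yl gives a 4.4-fold higher number from compound 1 to compound 4 (0.64 log units; beyond the scatter) and so weakens inhibition by more than the usual scatter. The two groups have the same heavy-atom count and are both six-membered aromatic rings, so the counted differences are a single ring carbon exchanged for nitrogen and the hydrogen-bond acceptor that enters with it. This pair shows that the change has a measurable cost at this position, but no evidence here explains why the number rises.

The compounds shown leave open whether the ring nitrogen has the same cost elsewhere in the ring, a question that pyridin-3-yl and pyridin-4-yl would address, and whether a carbon-based substituent such as a methoxy group on the phenyl ring would shift the number in either direction. They also leave open whether the methyl on the saturated ring carbon, which gives a 2.2-fold lower number from compound 1 to compound 2 (0.34 log units; beyond the scatter), would bring a similar change when pyridin-2-yl is present.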